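A few compounds are considered here, and "the series" means these few. Any claim that something is new, unique, unknown or untested is made for them only; others in the source may bear on it.

Measured so far in a functional assay on MDA-MB-436 cells (Homo sapiens) for antiproliferative activity, read by MTT assay, with a stated time of 48 h; a lower number here means a stronger inhibitor, a higher number a weaker inhibitor
- compound 1 `C=CS(=O)(=O)N1CCN(c2ncnc3ccc(-c4ccccc4)cc23)CC1` gives 23400 nM
- compound 2 `C=CS(=O)(=O)N1CCN(c2ncnc3sc(-c4ccc(OC)nc4)cc23)CC1` gives 11900 nM
- compound 3 `CN1CCN(c2ccc(-c3cc4c(N5CCN(C(=O)Nc6ccccc6)CC5)ncnc4s3)cc2)CC1` gives 7090 nM

Compound 3 (7090 nM) sits within the scatter of compound 2 and beyond the scatter of compound 1, whose number is higher. Compound 4 `CN1CCN(c2ccc(-c3cc4c(N5CCN(C(=O)Nc6cccc(F)c6)CC5)ncnc4s3)cc2)CC1` differs from compound 3 by fluoro in place of hydrogen on an aromatic carbon on an aromatic carbon, with phenylcarbamoyl becoming (3-fluorophenyl)carbamoyl. Going by the values given here, no measured pair differs in one place only, so this change has no direct precedent. The expectation therefore leans on compound 3 (7090 nM) alone, and no step beyond the scatter is expected in this assay. The estimated 1.1-fold lower number from compound 3 to compound 4 (0.04 log units; within the scatter) is small. For compound 4 the estimated value is 6500 nM (expected range 3000 nM to 14000 nM).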

Compound 4, half-maximal inhibitory concentration: 18300 nM
Beside the measured number, compound 4's estimate is 2.8-fold (0.45 log units) below it; the measured number lies above the stated range.
By their numbers in this assay, from the lowest: compounds 3, 2, 4 and 1 (each within the scatter of the next, the first and the last beyond it).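

In this assay, going by these compounds alone, a change at one place can now be read for the first time: fluoro in place of hydrogen on the aromatic carbon meta to a large group gives a 2.6-fold higher number from compound 3 to compound 4 (0.41 log units; beyond the scatter), with the higher number marking a weaker inhibitor. This carbon of the phenylcarbamoyl ring is therefore not indifferent to substitution, at least for fluoro. Nothing available accounts for the step. On these data alone, whether chloro or methyl at this carbon would give a similar step stays open, as does whether fluoro on other carbons of this ring would.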